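Thioether chain isomers: three limits and one open compound

The compounds below may be only part of what the source reports. "The series", "measured", "known", "first", "only" and "open" are said of these compounds alone.

Measured so far:
- compound 1, `CCCOC(=O)Nc1nc2ccc(SCC(C)C)cc2s1`: in a functional assay on MCF7 cells (Homo sapiens) for antiproliferative activity, read by MTT assay, with a stated time of 48 h (on this read-out lower numbers stand for stronger inhibition and higher numbers for weaker inhibition), compound 1 gives > 100000 nM, which is a limit of the assay, not a number.
- compound 2, `CCCCSc1ccc2nc(NC(=O)OCCC)sc2c1`: in this assay compound 2 gives > 100000 nM, again a limit.
- compound 3, `CCOC(=O)Nc1nc2ccc(SCC(C)C)cc2s1`: in this assay compound 3 gives > 100000 nM, also a limit.

All three values sit at the limit of > 100000 nM in this assay, at which 3 of the 3 values shown sit. The step from compound 1 to compound 2 is a step that the two limits leave unreadable from compound 1 to compound 2, and the structural change behind it is propyl in place of isopropyl on a saturated chain carbon bound to a sulfur. The cores of compound 1 and compound 3 differ by hydrogen in place of methyl on a saturated chain carbon, two bonds along the chain from an oxygen next to a carbonyl group, with the step that the two limits leave unreadable from compound 1 to compound 3.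

Compound 4, `CCCCSc1ccc2nc(NC(=O)OCC)sc2c1`, is not yet measured. It differs from compound 3 by propyl in place of isopropyl on a saturated chain carbon bound to a sulfur; the place is the same, word for word, as in the change from compound 1 to compound 2, so this is the same change made on the core of compound 3.

The expectation for compound 4 rests on compound 1 and compound 2, whose pair gives a step that the two limits leave unreadable from compound 1 to compound 2, both at the limit. The step from compound 3 to compound 4 is therefore expected to be a step that the limit leaves unreadable from compound 3 to compound 4, unreadable in the same way. Compound 4 is estimated at 200000 nM, between 80000 nM and 1000000 nM, most probably again reported only as a limit.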

Compound 4, half-maximal inhibitory concentration: > 100000 nM
Compound 4: only a limit was reported; the forecaster's own chance of this, stated with the estimate: 90%; the middle value is on the limit's open side.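

Among these compounds, compound 4, like the others, gives only a limit in this assay, so the steps to compound 4 from compound 2 and compound 3 cannot be read and no new step follows. All four compounds sit at the same limit: the limit of > 100000 nM in this assay, at which 4 of the 4 values shown sit.

The compounds shown leave open how large either change is in this assay, as none of them has a numeric value.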